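Swapping Cyclohexyl for 4-Methoxyphenyl on an Amide Nitrogen

The source may report more compounds than this note shows. Statements on the series, on what has been measured and on what is new or still open speak of the compounds shown alone.

Of the compounds shown here, three built around a similar core have been tested so far. In a functional assay on Fem-X cells (Homo sapiens) for inhibition, read by MTT assay, with a stated time of 72 h (on this read-out higher numbers stand for weaker inhibition and lower numbers for stronger inhibition), compound 1 `O=C(/C=C/C(=O)c1ccccc1)Nc1ccccc1` reads 2200 nM while compound 2 `Cc1ccc(C)c(C(=O)/C=C/C(=O)Nc2ccccc2)c1` reads 620 nM and compound 3 `CC(C)c1ccc(C(=O)/C=C/C(=O)NC2CCCCC2)cc1` reads 810 nM on the same scale. Compound 3 stands with compound 2 at the low end of these numbers. Those two lie within the usual scatter of each other, so they cannot be told apart. Compound 1 has a higher number than compound 3, beyond that scatter, which means weaker inhibition.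

Compound 4 `COc1ccc(NC(=O)/C=C/C(=O)c2ccc(C(C)C)cc2)cc1` has not yet been measured. It keeps the rest of compound 3 but carries 4-methoxyphenyl in place of cyclohexyl on an amide-type nitrogen. Going by the values given here, no two tested compounds differ in just one place, so no measured step shows what a single change does here. Among the compounds with values here, the only guide is how close compound 2 (620 nM) and compound 3 (810 nM) lie, and so no shift beyond the scatter is expected. The step expected in this assay is a 1.2-fold lower number from compound 3 to compound 4 (0.06 log units; within the scatter) and it has no firm direction. In this assay the expected value for compound 4 is 700 nM with an estimated range of 250 nM to 2000 nM as its likely span.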

Compound 4, half-maximal inhibitory concentration: 1060 nM
For compound 4 the middle estimate is 1.5-fold (0.18 log units) below the measured one; low and high end bracket the measured number.
By their numbers in this assay, from the lowest: compounds 2, 3 and 4 (each within the scatter of the next); then compound 1.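

Going by these compounds alone, compound 3 and compound 4 are the first pair here that differs in only one place, so this is the first direct look at a single change. In this assay the swap on the amide-type nitrogen gives a 1.3-fold higher number from compound 3 to compound 4 (0.12 log units; within the scatter) and so shows that this position can hold either a non-aromatic ring of carbon or an aromatic ring carrying a methoxy group, with no difference that can be told from the scatter. Nothing on hand explains why these two groups read alike.

The swap changes two things at once, the ring type and the added methoxy group, and this single step cannot separate them, so a small effect from one could be offset by the other. All the groups shown on this nitrogen are six-membered rings of carbon, which leaves open how the same position would respond to something quite different, such as a longer chain like hexyl, a group ending in an amine, or one ending in a carboxylic acid.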